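The source may report more compounds than this note shows. Statements on the series, on what has been measured and on what is new or still open speak of the compounds shown alone.

The compounds here were tested in a toxicity assay on HepG2 2.2.15 cells (Homo sapiens) for cytotoxicity, read by CellTiter-Glo; on this read-out higher numbers stand for lower toxicity in this test and lower numbers for higher toxicity in this test. Among the measured compounds shown here, compound 2 `O=C1c2ccccc2CN1c1cnn2c1CN(C(=O)Nc1cc(F)c(F)c(F)c1)C(C1CC1)C2` gives 38500 nM in this assay, and this is the only plain number among the results so far. For compound 1 `O=C(Nc1cc(F)c(F)c(F)c1)N1CCCn2ncc(N3CC(c4ccccc4)CC3=O)c2C1` the result in this assay is a limit of the test rather than a number, > 2000 nM. One number and one limit is thus what there is: the limit of > 2000 nM in this assay, at which 1 of the 2 values shown sits.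

Compound 3 `O=C1CC(c2ccccc2)CN1c1cnn2c1CN(C(=O)Nc1cc(F)c(F)c(F)c1)C(C1CC1)C2` is the next one to be measured. It differs from compound 2 in a single place: a group of 12 heavy atoms (10 carbon, 1 nitrogen, 1 oxygen; one five-membered non-aromatic ring with 1 hetero atom, one six-membered aromatic ring of carbon only) in place of a group of 10 heavy atoms (8 carbon, 1 nitrogen, 1 oxygen; one five-membered non-aromatic ring with 1 hetero atom, one six-membered aromatic ring of carbon only), on an aromatic carbon. No pair of measured compounds differs in just one place, so there is no measured step to lean on, and the change itself gives no reason to expect toxicity to move.

The step from compound 2 to compound 3 in this assay is therefore expected to stay within the usual scatter, a 1.1-fold lower number from compound 2 to compound 3 (0.04 log units; within the scatter). Compound 3 is accordingly estimated at 35000 nM in this assay, with a range from 15000 nM to 80000 nM, and a fair chance that only a limit is reported.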

Compound 3, half-maximal cytotoxic concentration: 12800 nM
Compound 3: middle estimate off by 2.7-fold (0.44 log units), on the high side; measured number below the stated range.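

In this assay, placing the 2-oxo-4-phenylpyrrolidin-1-yl group on the aromatic carbon of the five-membered aromatic ring gives a 3.0-fold lower number from compound 2 to compound 3 (0.48 log units; beyond the scatter). Among the compounds shown here, this is the first measured sign that this position is not indifferent to what it carries, with the lower number standing for higher toxicity in this test. The effect appears even though the leaving and entering groups have the same ring types, hydrogen-bond donors, hydrogen-bond acceptors and net charge; however, nothing measured here explains the shift.

For the compounds shown here, compound 1, which carries the same 2-oxo-4-phenylpyrrolidin-1-yl group, gives only a limit of the assay, > 2000 nM, so its single difference from compound 3 cannot be read as a step. From the compounds shown here alone, it also remains open whether a quite different group in this place, such as a carboxylic acid or a simple amine, would move the number in the same direction or leave it where it is.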